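Tolerated concentration limits across amine variants of one core

This account rests on a few compounds, and the source may have more. Where it says the series, first, only, none or still open, it means among the compounds named here.

Compound 1 `COc1cc2cc(C#N)ccc2c(OC)c1Oc1cc(NC(C)C)nc(Nc2ccc(C#N)cc2)n1` gives > 125000 nM in an ADME assay on MT4 cells (Homo sapiens) for cytotoxicity, read by MTT assay, with a stated time of 5 days (a higher number here means that more compound is tolerated, a lower number that less compound is tolerated), a limit of the assay rather than a number.
Compound 2 `CCCC(CCC)Nc1cc(Oc2c(OC)cc3cc(C#N)ccc3c2OC)nc(Nc2ccc(C#N)cc2)n1` gives > 125000 nM, again a limit of the assay.
Compound 3 `COc1cc2cc(C#N)ccc2c(OC)c1Oc1cc(NCC2CC2)nc(Nc2ccc(C#N)cc2)n1` gives > 125000 nM, likewise a limit of the assay.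

Compound 1 therefore stands only at a limit, as do the other two values: the limit of > 125000 nM in this assay, at which 3 of the 3 values shown sit. Among the measured compounds shown here, the steps a step that the two limits leave unreadable from compound 1 to compound 2, a step that the two limits leave unreadable from compound 1 to compound 3 and a step that the two limits leave unreadable from compound 2 to compound 3 cannot be read in size, so they show only that changing the group on this nitrogen has not brought any compound into the measurable range. Compound 4 `COc1cc2cc(C#N)ccc2c(OC)c1Oc1cc(NC2CCOCC2)nc(Nc2ccc(C#N)cc2)n1` differs from compound 1 by oxan-4-yl in place of isopropyl on a nitrogen on an aromatic ring. For the measured compounds named here, none of the measured steps gives a readable size, so no step beyond the scatter is expected for compound 4, and its expected step is a step that the limit leaves unreadable from compound 1 to compound 4. Compound 4 is estimated at 200000 nM, within 90000 nM to 600000 nM, most likely reported again as a limit.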

Compound 4, half-maximal cytotoxic concentration: > 125000 nM
Compound 4: only a limit was reported; the forecaster's own chance of this, stated with the estimate: 85%; the middle value lies beyond the limit too.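

Compound 4 also gives only a limit, so its steps from compound 1, compound 2 and compound 3 cannot be read in size: the limit of > 125000 nM in this assay, at which 4 of the 4 values shown sit. The compounds shown leave open where the true half-maximal cytotoxic concentration of any of compounds 1 to 4 lies.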